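Removing a Chloro from the Core of Compound 2

The source may report more compounds than this note shows. Statements on the series, on what has been measured and on what is new or still open speak of the compounds shown alone.

Three chloromethyl-benzyl purine analogues have been tested in a functional assay on KM12 cells (Homo sapiens) for cytotoxicity, read by sulforhodamine B assay, with a stated time of 48 h; on this read-out higher numbers stand for lower toxicity in this test and lower numbers for higher toxicity in this test. Compound 1 `ClCc1ccccc1Cn1cnc2c(Cl)nc(Cl)nc21` gives 5880 nM, compound 2 `ClCc1ccc(Cn2cnc3nc(Cl)nc(Cl)c32)cc1` gives 2450 nM, and compound 3 `ClCc1ccccc1Cn1cnc2ncnc(Cl)c21` gives 38000 nM. Compound 2 therefore stands at the lowest number of the three, meaning the strongest effect in this assay; its nearest neighbour is compound 1, with a number beyond the usual scatter, and the furthest is compound 3, far beyond it.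

Compound 4 `ClCc1ccc(Cn2cnc3ncnc(Cl)c32)cc1` has not yet been measured. It differs from compound 2 in one place: hydrogen in place of chloro on an aromatic carbon. Among the compounds with values here, no measured pair differs in exactly this way, so nothing can be computed directly. What the values do show is that compound 1, carrying two chloro groups on its core, gives 5880 nM, while compound 3, with only one, gives 38000 nM, a much higher number.

On that basis, a clear loss of effect is expected from compound 2 to compound 4, well beyond the scatter, and the expected step is a 6.1-fold higher number from compound 2 to compound 4 (0.79 log units; beyond the scatter). Compound 4 is estimated to give about 15000 nM in this assay, within a range from 5000 nM to 45000 nM.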

Compound 4, concentration lethal to 50% of the cells: 7070 nM
Beside the measured number, compound 4's estimate is 2.1-fold (0.33 log units) above it; the range from low to high includes it.
By their numbers in this assay, from the lowest: compound 2; then compounds 1 and 4 (each within the scatter of the next); then compound 3.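

In this assay, replacing the chloro on an aromatic carbon between two ring nitrogen atoms with hydrogen gives a 2.9-fold higher number from compound 2 to compound 4 (0.46 log units; beyond the scatter), a modest loss of effect that can now be read directly from a pair differing in this one place. With the chloromethyl group on the benzyl ring unchanged, the result shows that this chloro matters to the effect in this test but is not essential to it, since compound 4 still has a measurable lethal concentration on these cells. No measurement here explains how this chloro affects the number.

At this position the compounds shown carry only chloro or hydrogen, so it remains open what an amine, a methoxy group or a fluoro group would do there. From the compounds shown here alone, it also remains open whether this change has the same size when the chloromethyl group sits elsewhere on the benzyl ring, a question that the printed values of compound 1 at 5880 nM and compound 3 at 38000 nM raise but do not settle.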